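A few compounds are considered here, and "the series" means these few. Any claim that something is new, unique, unknown or untested is made for them only; others in the source may bear on it.

Measured compounds in an assay on isolated protein for displacement of a labelled ligand from Bcl2-associated agonist of cell death (Homo sapiens), read by fluorescence polarization; on this read-out higher numbers stand for weaker inhibition and lower numbers for stronger inhibition:
Compound 1 `CN(C)CC[C@H](CSc1ccccc1)Nc1ccc(S(=O)(=O)NC(=O)c2ccc(N3CCN(Cc4ccccc4-c4ccc(Cl)cc4)CC3)cc2)cc1S(C)(=O)=O` gives < 1 nM, which is a limit of this assay rather than a number.
Compound 2 `CN(C)CC[C@H](CSc1ccccc1)Nc1ccc(S(=O)(=O)NC(=O)c2ccc(N3CCN(Cc4ccccc4-c4ccc(Cl)cc4)CC3)cc2)cc1` gives 14 nM.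
Compound 3 `CN(C)CC[C@H](CSc1ccccc1)Nc1ccc(S(=O)(=O)NC(=O)c2ccc(N3CCN(CC4=C(c5ccc(Cl)cc5)CCOC4)CC3)cc2)cc1[N+](=O)[O-]` gives < 1 nM, again a limit of this assay rather than a number.

Within the data shown here, compound 2 therefore stands as the only compound of the three with a number in this assay; the other two values are limits. Among the measured compounds shown here, the one measured step that touches this position is an at least 14-fold higher number from compound 1 to compound 2 (1.14 log units; beyond the scatter), a large step in the weaker direction when the methylsulfonyl is removed. For the measured compounds named here, compound 3 sits at the limit of < 1 nM in this assay, at which 2 of the 3 values shown sit, with a nitro group on the same aromatic carbon, though its biaryl part differs, so no single step joins it to compound 2.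

Compound 4 `CN(C)CC[C@H](CSc1ccccc1)Nc1ccc(S(=O)(=O)NC(=O)c2ccc(N3CCN(Cc4ccccc4-c4ccc(Cl)cc4)CC3)cc2)cc1C#N` differs from compound 2 by cyano in place of hydrogen on an aromatic carbon. Since compound 1 shows that occupying this aromatic carbon with methylsulfonyl strengthens binding by an at least 14-fold higher number from compound 1 to compound 2 (1.14 log units; beyond the scatter), a step in the stronger direction is expected here too, though its full size cannot be read because compound 1 sits at the limit of < 1 nM in this assay, at which 2 of the 3 values shown sit. Compound 4 is therefore estimated at 1.5 nM (range 0.5 nM to 5 nM), meaning an expected step of a 9.3-fold lower number from compound 2 to compound 4 (0.97 log units; beyond the scatter), with a fair chance that this assay again reports only a limit.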

Compound 4, inhibition constant: < 1 nM
Compound 4: no number, only a limit; the forecaster's own chance of this, stated with the estimate: 45%; middle value at least 1.5-fold (0.17 log units) from the limit.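

In this assay, the step of an at least 14-fold lower number from compound 2 to compound 4 (1.14 log units; beyond the scatter) shows that the stronger binding at this aromatic carbon is not tied to methylsulfonyl: cyano, with only 2 heavy atoms and no ring, also gives a large move away from the hydrogen of compound 2. Compound 4 gives < 1 nM, which is a limit of the assay and not a number, so the true size of this step stays hidden. The step from compound 1 to compound 4 cannot be read, so cyano and methylsulfonyl cannot be ranked at this position, and the series now crowds at one end of the read-out: the limit of < 1 nM in this assay, at which 3 of the 4 values shown sit.

The compounds shown leave open whether a single fluorine or a methyl on this aromatic carbon would already give the same move away from hydrogen, and whether an amine or a carboxylic acid there would keep it. They also leave open how cyano would fare on the core of compound 3, which carries a nitro group on the same carbon but differs in its biaryl part.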